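A few compounds are considered here, and "the series" means these few. Any claim that something is new, unique, unknown or untested is made for them only; others in the source may bear on it.

The compounds measured so far:
Compound 1, `COc1ccc(-c2cc(NC(=O)CCC(=O)NCC(=O)NCc3ccccc3)nc(-c3ccc(OC)cc3)n2)cc1`, in an assay on HeLa cells for displacement of a labelled ligand from adenosine receptor A3 (Homo sapiens), read by fluorescence polarization, with a stated time of 30 min (on this read-out lower numbers stand for stronger inhibition and higher numbers for weaker inhibition), gives 26900 nM.
Compound 2, `COc1ccc(-c2cc(NC(=O)COCC(=O)NCC(=O)NC(C)(C)C)nc(-c3ccc(OC)cc3)n2)cc1`, gives 11200 nM.
Compound 3, `COc1ccc(-c2cc(NC(=O)COCC(=O)NCC(=O)NC3CCCCC3)nc(-c3ccc(OC)cc3)n2)cc1`, gives 14000 nM.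

On these numbers compound 3 stands second highest of three. Its nearest neighbour is compound 2, and the gap between the two lies within the scatter; its furthest is compound 1, and that gap too lies within the scatter. So the three values cannot be put in any order that means something.

Compound 4, `COc1ccc(-c2cc(NC(=O)COCC(=O)NCC(=O)NCc3ccccc3)nc(-c3ccc(OC)cc3)n2)cc1`, has not yet been measured in this assay. It differs from compound 3 by benzyl in place of cyclohexyl on an amide-type nitrogen. For the measured compounds named here, only one measured single change touches the group on that amide-type nitrogen: cyclohexyl in place of tert-butyl, with a 1.3-fold higher number from compound 2 to compound 3 (0.10 log units; within the scatter), which stayed within the scatter. Going by the values given here, compound 1 also carries a benzyl on an amide-type nitrogen but with a different chain, so no single step joins it to compound 4; its value and that of compound 3 sit within the scatter of each other. A step of a 1.1-fold higher number from compound 3 to compound 4 (0.06 log units; within the scatter) is therefore expected, none beyond the scatter. Compound 4 is estimated at 16000 nM, within 6000 nM to 45000 nM.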

Compound 4, inhibition constant: 64600 nM
Estimate against measurement, compound 4: 4.0-fold (0.61 log units) below; measured number above the stated range.
By their numbers in this assay, from the lowest: compounds 2, 3 and 1 (each within the scatter of the next, the first and the last beyond it); then compound 4.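

In this assay the group on the amide-type nitrogen proves not to be freely interchangeable: benzyl in place of cyclohexyl brings a 4.6-fold higher number from compound 3 to compound 4 (0.66 log units; beyond the scatter) and benzyl in place of tert-butyl brings a 5.8-fold higher number from compound 2 to compound 4 (0.76 log units; beyond the scatter), both beyond the scatter, whereas the earlier swap of tert-butyl for cyclohexyl stayed within it. Cyclohexyl and benzyl each hold a six-membered ring of carbon only, one non-aromatic and one aromatic, and neither has a hydrogen-bond donor or acceptor, so this position responds to a difference those counts do not capture. Nothing measured here explains the result.

The compounds shown cannot separate the aromatic ring from the carbon linking it to the nitrogen; a phenyl or a cyclohexylmethyl group there would tell these apart. Also open, as far as these compounds go, is how a longer chain such as phenethyl, or a benzyl carrying a carboxylic acid, would read.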